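Benzyl Triazole Chromone Series: From Fluoro to Cyano

The source may report more compounds than this note shows. Statements on the series, on what has been measured and on what is new or still open speak of the compounds shown alone.

Four benzyl-triazole ethers of a shared chromone core are considered here. Compound 1 `O=c1ccoc2cc(OCc3cn(Cc4ccccc4)nn3)ccc12` carries the plain benzyl group; in a functional assay on QGY7701 cells (Homo sapiens) for cytotoxicity, read by MTT assay, with a stated time of 48 h (a higher number here means a weaker inhibitor, a lower number a stronger inhibitor), compound 1 is reported only as a limit, > 100000 nM. Compound 2 `Cc1cccc(Cn2cc(COc3ccc4c(=O)ccoc4c3)nn2)c1` gives 22400 nM in this assay, and compound 3 `O=c1ccoc2cc(OCc3cn(Cc4ccccc4F)nn3)ccc12` gives 36900 nM there. Among the two numbers shown, compound 3 stands highest, with compound 2 nearest, although a 1.6-fold higher number from compound 2 to compound 3 (0.22 log units; within the scatter). Both substituted benzyl groups clear the limit seen for compound 1: an at least 4.4-fold lower number from compound 1 to compound 2 (0.64 log units; beyond the scatter) and an at least 2.7-fold lower number from compound 1 to compound 3 (0.43 log units; beyond the scatter).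

Compound 4 `N#Cc1ccc(Cn2cc(COc3ccc4c(=O)ccoc4c3)nn2)cc1` differs from compound 3 by 4-cyanophenyl in place of 2-fluorophenyl on a saturated chain carbon bound to an aromatic nitrogen. Among the compounds with values here, no measured step involves a nitrile; the two informative steps, from compound 1, concern methyl and fluoro only, and the one step between two substituted benzyl groups, from compound 2 to compound 3, lies within the scatter. The swap of one ring substituent for another is therefore expected to give no step beyond the scatter in this assay, with a real possibility that compound 4 returns only a limit. Compound 4 is estimated to give 35000 nM in this assay, within 12000 nM to 100000 nM, a change expected as a 1.1-fold lower number from compound 3 to compound 4 (0.02 log units; within the scatter).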

Compound 4, half-maximal inhibitory concentration: > 100000 nM
Compound 4 was reported as a limit; the forecaster's own chance of this, stated with the estimate: 25%; middle value at least 2.8-fold (0.45 log units) away from the limit.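

Unlike the swap between the two substituted benzyl groups of compound 2 and compound 3, the change to 4-cyanobenzyl at this place, on a saturated chain carbon bound to an aromatic nitrogen, goes beyond the scatter in this assay: the result is an at least 2.7-fold higher number from compound 3 to compound 4 (0.43 log units; beyond the scatter), and likewise an at least 4.4-fold higher number from compound 2 to compound 4 (0.64 log units; beyond the scatter). The earlier compounds shown here suggested that a substituent on the benzyl ring brings a readable number, but compound 4 goes against this, so the pattern holds only for compound 2 and compound 3, the methyl and fluoro cases. The step between compound 1 and compound 4 cannot be read, and compound 4 joins compound 1 as a limit rather than a number: the limit of > 100000 nM in this assay, at which 2 of the 4 values shown sit.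

The compounds shown change the substituent and its ring position together, so they leave open whether the nitrile or its place on the ring accounts for the loss of a readable value. Going by these compounds, how an amine, a carboxylic acid or a methoxy group on the benzyl ring would read in this assay also remains open.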